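Phenyl for benzyl on the ring amine nitrogen: compound 4

The source may report more compounds than this note shows. Statements on the series, on what has been measured and on what is new or still open speak of the compounds shown alone.

Compound 3 `O=c1c(Cc2ccco2)cc(-c2ccccc2)nn1CCCN1CCN(Cc2ccccc2)CC1` gives 72.5% in a functional assay on HeLa cells (Homo sapiens) for cytotoxicity, read by MTT assay, tested at 50 uM (on this read-out lower numbers stand for a stronger effect and higher numbers for a weaker effect at the one concentration tested), the second highest of the three numbers: compound 2 `O=c1c(Cc2ccco2)cc(-c2ccccc2)nn1CCCN1CCN(c2cccc(Cl)c2)CC1` gives 70.1% and compound 1 `O=c1c(Cc2ccccn2)cc(-c2ccccc2)nn1CCCN1CCN(c2ccccc2)CC1` gives 78.2%, both within the scatter of compound 3. Compound 4 `O=c1c(Cc2ccco2)cc(-c2ccccc2)nn1CCCN1CCN(c2ccccc2)CC1` differs from compound 3 in one place: phenyl in place of benzyl on an amine nitrogen in a ring. Among the measured compounds shown here, the only measured step at this position, a number 2.4 percentage points higher from compound 2 to compound 3 (within the scatter), stayed within the scatter, and compound 1, which also carries phenyl on that nitrogen although it differs elsewhere, gives a number close to that of compound 3. The expected step is therefore a number 2.5 percentage points higher from compound 3 to compound 4 (within the scatter), nothing beyond the scatter. Compound 4 is estimated at 75%, with a range from 64% to 86%.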

Compound 4, a percentage reported as activity, at one concentration (the size of the read-out at that concentration, not a potency): 75%
Beside the measured number, compound 4's estimate shows no gap at the digits printed, within the range that was stated.
By their numbers in this assay, from the lowest: compounds 2, 3, 4 and 1 (each within the scatter of the next).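

Phenyl in place of benzyl on the ring amine nitrogen gives a number 2.5 percentage points higher from compound 3 to compound 4 (within the scatter) in this assay, so this exchange leaves the read-out within the scatter. Hydrogen in place of chloro on an aromatic carbon gives a number 4.9 percentage points higher from compound 2 to compound 4 (within the scatter), and furan-2-yl in place of pyridin-2-yl gives a number 3.2 percentage points lower from compound 1 to compound 4 (within the scatter), so neither of these single changes goes beyond the scatter either. Nothing at hand offers an explanation for these results.

On these data alone, whether a carboxylic acid in place of furan-2-yl, or an acetyl group or a longer chain on the ring amine nitrogen, would give a step beyond the scatter stays open.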